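This account rests on a few compounds, and the source may have more. Where it says the series, first, only, none or still open, it means among the compounds named here.

Measured so far in an assay on isolated protein for inhibition of protein deacetylase HDAC6 (Homo sapiens), tested at 0.5 uM; on this read-out higher numbers stand for more inhibition at the one concentration tested (going by the name of the read-out) and lower numbers for less inhibition:
- compound 1 `CN1CCN(c2nc(-c3ccc(C(=O)NO)cc3)nc3ccccc23)CC1`: 89.4%
- compound 2 `O=C(NO)c1ccc(-c2nc(N3CCCC3)c3ccc(Cl)cc3n2)cc1`: 54.6%
- compound 3 `O=C(NO)c1ccc(-c2nc(N3CCCCC3)c3ccc(Cl)cc3n2)cc1`: 59.6%

Compound 3 stands second highest of the three numbers: its nearest neighbour is compound 2, with a number 5 percentage points higher from compound 2 to compound 3 (within the scatter), and the furthest is compound 1, whose number lies beyond the scatter above it. Compound 4 `CN1CCN(c2nc(-c3ccc(C(=O)NO)cc3)nc3cc(Cl)ccc23)CC1` has not yet been measured. It differs from compound 3 in one place: 4-methylpiperazin-1-yl in place of piperidin-1-yl on an aromatic carbon. Going by the values given here, the only measured step, the one from compound 2 to compound 3, swaps one ring for another of a different size and does not bear on this change. Compound 1 carries the same 4-methylpiperazin-1-yl group as compound 4 but lacks the chlorine of compound 3, so its value can only hint at direction. Because compound 1 gives 89.4%, compound 4 is expected to move upward from compound 3 by a number 15.4 percentage points higher from compound 3 to compound 4 (beyond the scatter). The estimate for compound 4 in this assay is 75%, within 55% to 92%.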

Compound 4, a percentage reported as inhibition, at one concentration (the size of the read-out at that concentration, not a potency): 94.4%
The estimate for compound 4 lay 19.4 percentage points below the measured number, outside the stated range (above it).
By their numbers in this assay, from the lowest: compounds 2 and 3 (each within the scatter of the next); then compounds 1 and 4 (each within the scatter of the next).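

In this assay, the ring on the aromatic carbon next to the ring nitrogen proves to matter a great deal: 4-methylpiperazin-1-yl in place of piperidin-1-yl gives a large gain (a number 34.8 percentage points higher from compound 3 to compound 4 (beyond the scatter)), and 4-methylpiperazin-1-yl in place of pyrrolidin-1-yl gives a similar one (a number 39.8 percentage points higher from compound 2 to compound 4 (beyond the scatter)), whereas the earlier ring swap had shown no readable change. With 4-methylpiperazin-1-yl in place, chloro instead of hydrogen makes no readable difference (a number 5 percentage points higher from compound 1 to compound 4 (within the scatter)). No measurement here explains the gain.

From the compounds shown here alone, it remains open whether the gain follows the second ring nitrogen or its methyl, which a piperazin-1-yl without the methyl or a morpholin-4-yl at this position would help to separate. Going by these compounds, whether chloro is equally silent alongside piperidin-1-yl also remains open.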